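The source may report more compounds than this note shows. Statements on the series, on what has been measured and on what is new or still open speak of the compounds shown alone.

Of the compounds shown here, three have been tested in a functional assay on A549 cells (Homo sapiens), read by MTT assay, with a stated time of 72 h; a lower number here means a stronger inhibitor, a higher number a weaker inhibitor. Among the measured compounds shown here, compound 1 `C#Cc1cn([C@@H]2O[C@H](CO)[C@@H](O)[C@H]2O)c2ncnc(N(C)C)c12` gives 390 nM, the only true number among them. Compound 2 `Nc1nc(N)c2c(-c3cc4ccccc4o3)cn([C@@H]3O[C@H](CO)[C@@H](O)[C@H]3O)c2n1` reads > 20000 nM, which is a limit of the assay and not a number. Compound 3 `Nc1nc2c(c(-c3cccs3)cn2[C@@H]2O[C@H](CO)[C@@H](O)[C@H]2O)c(=O)[nH]1` reads > 20000 nM, which is also only a limit. Compound 3 therefore stands at the limit of > 20000 nM in this assay, at which 2 of the 3 values shown sit, alongside compound 2.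

Compound 4 `Nc1nc2c(c(-c3cc4ccccc4o3)cn2[C@@H]2O[C@H](CO)[C@@H](O)[C@H]2O)c(=O)[nH]1` has not yet been measured. It has 1-benzofuran-2-yl in place of thiophen-2-yl on an aromatic carbon of compound 3: 1-benzofuran-2-yl in place of thiophen-2-yl on an aromatic carbon. For the measured compounds named here, no measured pair shows what this swap does on its own. The closest guide is compound 2, which already carries 1-benzofuran-2-yl and reads > 20000 nM, again a limit.

On that basis, no step beyond the usual scatter is expected in this assay, and a reading at the limit is a likely outcome. The expected step is a number no higher from compound 3 to compound 4 (the limit leaves the size open). For compound 4 the estimate is 20000 nM, with an expected range of 9000 nM to 40000 nM.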

Compound 4, half-maximal inhibitory concentration: > 100000 nM
Compound 4: a limit, no number; the forecaster's own chance of this, stated with the estimate: 75%; at least 5.0-fold (0.69 log units) between middle value and limit.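

In this assay, compound 3 and compound 4 each give only a limit of the assay and not a number, so no step can be read between them. The compounds shown leave open what 1-benzofuran-2-yl in place of thiophen-2-yl does on its own.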